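This account rests on a few compounds, and the source may have more. Where it says the series, first, only, none or still open, it means among the compounds named here.

Measured in a functional assay on HSC-2 cells (Homo sapiens) for cytotoxicity, with a stated time of 24 h; on this read-out higher numbers stand for lower toxicity in this test and lower numbers for higher toxicity in this test:
compound 1 `COc1cc(/C=C2\CCC/C(=C\c3ccccc3[N+](=O)[O-])C2=O)cc(OC)c1OC`: 5900 nM
compound 2 `COc1ccc(/C=C2\CCC/C(=C\c3cccc([N+](=O)[O-])c3)C2=O)cc1`: 4800 nM
compound 3 `COc1ccc(/C=C2\CCC/C(=C\c3ccc([N+](=O)[O-])cc3)C2=O)cc1`: > 400000 nM (a limit of the assay, not a number)

Compound 1 at 5900 nM lies within the usual scatter of compound 2 at 4800 nM. Going by the values given here, these are the only two numbers in the set, as the third result is a limit.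

The next compound to be tested is compound 4 `COc1cc(/C=C2\CCC/C(=C\c3ccc([N+](=O)[O-])cc3)C2=O)cc(OC)c1OC`. Against compound 1 the change is 4-nitrophenyl in place of 2-nitrophenyl on a double-bonded chain carbon bound to a double-bonded ring carbon. The two compounds have the same atoms, joined differently, and the rest of the core of compound 1 stays as it is.

Among the compounds with values here, no measured pair in the set isolates this change, so the expectation is indirect and uncertain. A step to a higher number in this assay, beyond the scatter, is expected on the evidence of compound 3, which also carries 4-nitrophenyl and gives > 400000 nM, a limit of the assay. The estimated step is a 5.1-fold higher number from compound 1 to compound 4 (0.71 log units; beyond the scatter). For compound 4 the estimated value is 30000 nM, with an expected range from 5000 nM to 300000 nM.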

Compound 4, half-maximal cytotoxic concentration: 760 nM
Compound 4: middle estimate off by 39-fold (1.60 log units), on the high side, outside the stated range (below it).
By their numbers in this assay, from the lowest: compound 4; then compounds 2 and 1 (each within the scatter of the next). At a limit, above all of these: compound 3.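

In this assay, 4-nitrophenyl in place of 2-nitrophenyl on a double-bonded chain carbon bound to a double-bonded ring carbon gives a 7.8-fold lower number from compound 1 to compound 4 (0.89 log units; beyond the scatter). Going by these compounds alone, this is the first step that can be read, and with the same atoms in both compounds, it shows that the way the nitrophenyl group is joined is enough to move the number beyond the scatter, here towards higher toxicity in this test. Compound 3 also carries 4-nitrophenyl but stands at a limit and not at a number, and compound 4 shows that 4-nitrophenyl alone does not bring a compound to that limit: the limit of > 400000 nM in this assay, at which 1 of the 4 values shown sits.

Going by these compounds, compound 2 and compound 3 differ in their nitrophenyl group, but the step between them cannot be read, so whether the direction seen here holds on the core they share stays open. Also open, on these data alone, is how an amine or a carboxylic acid in place of the nitro group of 4-nitrophenyl would read in this assay.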